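The source may hold more compounds than are shown below. What is called first, only, known or untested is meant among the compounds shown, and "the series" means these compounds.

Three compounds built on one shared core were compared in an ADME assay on MT4 cells (Homo sapiens) for cytotoxicity, read by MTT assay; a higher number here means that more compound is tolerated, a lower number that less compound is tolerated. Compound 1 `O=C1c2ccccc2C(=O)N1CCOC(=S)N(C(=O)c1c(F)cccc1F)c1ccc(Cl)cc1` gives 39000 nM in this assay. Compound 2 `O=C1c2ccccc2C(=O)N1CCOC(=S)N(C(=O)c1cc(F)cc(F)c1)c1ccc(Cl)cc1` carries 3,5-difluorophenyl in place of 2,6-difluorophenyl on a carbonyl carbon, and in this assay compound 2 gives 59000 nM, a step of a 1.5-fold higher number from compound 1 to compound 2 (0.18 log units; within the scatter). Compound 3 `Cc1ccc(N(C(=O)c2c(F)cccc2F)C(=S)OCCN2C(=O)c3ccccc3C2=O)cc1` differs from compound 1 by methyl in place of chloro on an aromatic carbon, and in this assay compound 3 gives 65000 nM, a step of a 1.7-fold higher number from compound 1 to compound 3 (0.22 log units; within the scatter). All three numbers sit within the usual scatter of one another, so no order among them can be claimed.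

Compound 4 `Cc1ccc(N(C(=O)c2cc(F)cc(F)c2)C(=S)OCCN2C(=O)c3ccccc3C2=O)cc1` has not yet been measured in this assay. It differs from compound 3 by 3,5-difluorophenyl in place of 2,6-difluorophenyl on a carbonyl carbon, the same change that separates compound 1 from compound 2, here made on the core of compound 3 rather than that of compound 1. Because the earlier instance of this change gave a 1.5-fold higher number from compound 1 to compound 2 (0.18 log units; within the scatter) and stayed within the scatter, the step from compound 3 to compound 4 is expected to be similarly small, estimated as a 1.2-fold higher number from compound 3 to compound 4 (0.09 log units; within the scatter). Compound 4 is therefore expected to give about 80000 nM, most likely between 40000 nM and 160000 nM.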

Compound 4, half-maximal cytotoxic concentration: 54000 nM
For compound 4 the middle estimate is 1.5-fold (0.17 log units) above the measured one; low and high end bracket the measured number.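

In this assay, the change to 3,5-difluorophenyl from 2,6-difluorophenyl on a carbonyl carbon gives a 1.2-fold lower number from compound 3 to compound 4 (0.08 log units; within the scatter), and the two instances of this change cannot be told apart: the same change on two cores in this assay, a 1.5-fold higher number (0.18 log units; within the scatter) from compound 1 to compound 2 and a 1.2-fold lower number (0.08 log units; within the scatter) from compound 3 to compound 4, 1.8-fold (0.26 log units) apart, within the scatter of two such steps. Methyl in place of chloro on an aromatic carbon, read on the second pair, gives a 1.1-fold lower number from compound 2 to compound 4 (0.04 log units; within the scatter), and here too the two instances cannot be told apart: the same change on two cores in this assay, a 1.7-fold higher number (0.22 log units; within the scatter) from compound 1 to compound 3 and a 1.1-fold lower number (0.04 log units; within the scatter) from compound 2 to compound 4, 1.8-fold (0.26 log units) apart, within the scatter of two such steps. Thus neither change moves the number beyond the scatter on either core, but this does not show that either change carries a fixed size or direction from one core to another, as all four steps are too small to establish one.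

The compounds shown leave open whether a different group in place of the chloro or methyl, such as an amine or a carboxylic acid, would give a step beyond the scatter. They also leave open whether a non-fluorinated phenyl or a pyridine in place of the difluorophenyl would do so.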